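The source may hold more compounds than are shown below. What is called first, only, known or untested is meant among the compounds shown, and "the series" means these compounds.

Measured compounds:
Compound 1 `Cc1ccc([C@H]2NC[C@@H](O)[C@@H]2O)cc1`: 0%
Compound 2 `O[C@H]1[C@H](O)CN[C@@H]1c1ccc(-c2ccccc2)cc1`: 0%

Of the compounds shown here, two sharing one core have been measured in an assay on isolated protein for inhibition of alpha-mannosidase (Canavalia ensiformis), read by spectrophotometry, tested at 1000 uM; a lower number here means less inhibition, a higher number more inhibition at the concentration tested (going by the name of the read-out). Compound 1 gives 0%, and compound 2 gives 0%. The one step between them, phenyl in place of methyl on an aromatic carbon, shows no change at the digits printed from compound 1 to compound 2 (within the scatter), so compound 2 stands level with compound 1 on the numbers shown, and neither compound inhibits at the concentration tested.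

Compound 3 `O[C@H]1[C@H](O)CN[C@@H]1c1ccc(F)cc1` has not yet been measured. It differs from compound 2 by fluoro in place of phenyl on an aromatic carbon. Within the data shown here, the only measured step that bears on it, the change at the same aromatic carbon from compound 1 to compound 2, produced no movement beyond the scatter. On that basis compound 3 is expected to stay where compound 2 stands, with a step of a number 2 percentage points higher from compound 2 to compound 3 (within the scatter). The estimate for compound 3 in this assay is 2%, within a range from 0% to 15%.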

Compound 3, a percentage reported as inhibition, at one concentration (the size of the read-out at that concentration, not a potency): 0.8%
The estimate for compound 3 lay 1.2 percentage points above the measured number; measured number inside the range.
By their numbers in this assay, from the lowest: compounds 1, 2 and 3 (each within the scatter of the next).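

In this assay, among these compounds, the aromatic carbon para to a group of 7 heavy atoms now carries a non-carbon substituent for the first time, where the earlier pair offered only methyl and phenyl. Fluoro in place of phenyl gives a number 0.8 percentage points higher from compound 2 to compound 3 (within the scatter), and fluoro in place of methyl gives a number 0.8 percentage points higher from compound 1 to compound 3 (within the scatter). So neither the swap from a phenyl of 6 heavy atoms to a fluoro of 1 heavy atom nor the swap from methyl to fluoro separates these compounds in this read-out, and nothing presented explains this flat result.

The compounds shown leave open whether any group at this carbon, such as an amine or a carboxylic acid, would give a measurable reading. They also leave open whether a change elsewhere on the shared core would do so.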